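Bromo removal in a fused two-ring series: compound 2 to compound 3

The source may hold more compounds than are shown below. What is called first, only, known or untested is meant among the compounds shown, and "the series" means these compounds.

Measured so far:
Compound 1 `Cc1ccc(-c2c(S(=O)(=O)c3ccccc3)cnc3cc(C)nn23)cc1`: 8.1%
Compound 2 `Cc1ccc(-c2c(S(=O)(=O)c3ccccc3)cnc3c(Br)c(-c4ccccc4)nn23)cc1`: 0%

Within the data shown here, in a functional assay on the whole organism for inhibition, with Mus musculus as the target, with a stated time of 5 h, at a dose of 50 mg/kg by the oral route (a lower number here means less inhibition, a higher number more inhibition at the dose given (going by the name of the read-out)), compound 2 gives 0%, the lowest of the two numbers so far. In this assay compound 1 gives 8.1%, a number higher by an amount within the usual scatter, so the two compounds are not distinguished. Compound 3 `Cc1ccc(-c2c(S(=O)(=O)c3ccccc3)cnc3cc(-c4ccccc4)nn23)cc1` differs from compound 2 by hydrogen in place of bromo on an aromatic carbon. Among the measured compounds shown here, no measured pair isolates this change, so its effect is not known from these data. With both measured neighbours low, the step of a number 5 percentage points higher from compound 2 to compound 3 (within the scatter) is expected to be small, none beyond the scatter, in either direction. Compound 3 is expected to give 5%, within 0% to 20%, because compound 2 gives 0%.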

Compound 3, a percentage reported as inhibition, in the whole organism at one dose (the size of the read-out at that dose, not a potency): 28.2%
For compound 3 the middle estimate is 23.2 percentage points below the measured one; measured number above the stated range.
By their numbers in this assay, from the lowest: compounds 2 and 1 (each within the scatter of the next); then compound 3.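

In this assay, hydrogen in place of bromo on this aromatic carbon gives a number 28.2 percentage points higher from compound 2 to compound 3 (beyond the scatter), so the substituent at this position matters once a phenyl group is present on the ring atom it stands next to. Phenyl in place of methyl on an aromatic carbon gives a number 20.1 percentage points higher from compound 1 to compound 3 (beyond the scatter), and both steps end at compound 3, the highest of the series. Nothing available explains either step.

As far as these compounds go, whether the step is specific to bromo remains open. Fluoro, methyl or an amine on this carbon could show whether any group there gives a low number.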